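Swapping the tert-butyl ester of compound 1 for a propyl ester

This account rests on a few compounds, and the source may have more. Where it says the series, first, only, none or still open, it means among the compounds named here.

Compound 1 `Cc1c(C(=O)OC(C)(C)C)c[nH]c1C(=O)OC(C)(C)C` is one of three pyrrole diesters assessed in an assay on CHO cells for inhibition of metabotropic glutamate receptor 1 (Rattus norvegicus); on this read-out higher numbers stand for weaker inhibition and lower numbers for stronger inhibition. In this assay compound 1 gives 100 nM, the second highest number of the three. For the measured compounds named here, its nearest neighbour is compound 3 `CCOC(=O)c1[nH]cc(C(=O)OC(C)(C)C)c1C`, which gives 340 nM; compound 2 `CCCOC(=O)c1[nH]cc(C(=O)OC(C)C(C)(C)C)c1C` gives 4 nM, the lowest number of the set and the one furthest from compound 1.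

The compound yet to be measured is compound 4 `CCCOC(=O)c1[nH]cc(C(=O)OC(C)(C)C)c1C`. It differs from compound 1 in one place: propyl in place of tert-butyl on an oxygen next to a carbonyl group.

Going by the values given here, only one measured step bears on this change. Shortening the same ester from tert-butyl to ethyl gave a 3.4-fold higher number from compound 1 to compound 3 (0.53 log units; beyond the scatter), a modest loss. Compound 2 carries a propyl ester at the same oxygen, but its other ester differs from that of compound 1 as well, so its low number cannot be attributed to the propyl group alone. With ethyl costing a modest amount and propyl being one carbon longer, the author expects at most a small shift for compound 4, a 1.1-fold lower number from compound 1 to compound 4 (0.05 log units; within the scatter), within or close to the scatter. Compound 4 is therefore estimated at 90 nM, with a range from 25 nM to 350 nM.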

Compound 4, half-maximal inhibitory concentration: 75 nM
Beside the measured number, compound 4's estimate is 1.2-fold (0.08 log units) above it; low and high end bracket the measured number.
By their numbers in this assay, from the lowest: compound 2; then compounds 4 and 1 (each within the scatter of the next); then compound 3.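

In this assay, the change reads as a 1.3-fold lower number from compound 1 to compound 4 (0.12 log units; within the scatter), so tert-butyl and propyl on this oxygen cannot be told apart, while the ethyl ester of compound 3 stands apart from both. One added carbon accounts for that separation: methyl in place of hydrogen on a saturated chain carbon, two bonds along the chain from an oxygen next to a carbonyl group, gives a 4.5-fold lower number from compound 3 to compound 4 (0.66 log units; beyond the scatter), a modest step. With the propyl ester held constant, tert-butyl in place of 1,2,2-trimethylpropyl on the other ester gives a 19-fold higher number from compound 2 to compound 4 (1.27 log units; beyond the scatter), which places the large gap at that group and not at the propyl ester.

The compounds shown leave open whether a longer chain such as butyl, or a cyclic group such as cyclohexyl, on this oxygen would stay level with propyl and tert-butyl. They also leave open whether 1,2,2-trimethylpropyl on the other ester would give as large a step alongside an ethyl or tert-butyl ester.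

No measurement at hand offers an explanation for any of these steps.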